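A few compounds are considered here, and "the series" means these few. Any claim that something is new, unique, unknown or untested is made for them only; others in the source may bear on it.

In a functional assay on A549 cells (Homo sapiens) for inhibition, read by sulforhodamine B assay, with a stated time of 48 h (a higher number here means a weaker inhibitor of growth, a lower number a stronger inhibitor of growth), compound 1 `COc1cc(/C=C/C(=O)/C=C/c2sccc2C)cc(OC)c1OC` gives 9310 nM and compound 2 `COc1ccc(/C=C/C(=O)C(=Cc2ccc(F)cc2)C(=O)/C=C/c2ccc(OC)c(OC)c2)cc1OC` gives 550 nM as the lower of the two numbers, a gap beyond the usual scatter. Compound 1 and compound 2 differ in much of their structure, so that gap cannot be tied to any single group. Compound 3 `COc1ccc(C=C(C(=O)/C=C/c2ccc(OC)c(OC)c2)C(=O)/C=C/c2ccc(OC)c(OC)c2)c(OC)c1` keeps the rest of compound 2 but carries 2,4-dimethoxyphenyl in place of 4-fluorophenyl on a double-bonded chain carbon bound to a double-bonded chain carbon. Among the measured compounds shown here, no measured pair shows what such a swap does, so only a small shift toward weaker growth inhibition is expected, possibly none beyond the scatter. The estimated size of the change is a 1.4-fold higher number from compound 2 to compound 3 (0.13 log units; within the scatter) and it remains an expectation. Compound 3 is expected at 750 nM (estimated range 250 nM to 2200 nM).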

Compound 3, concentration for 50% growth inhibition: 650 nM
Compound 3: middle estimate off by 1.2-fold (0.06 log units), on the high side; the range from low to high includes it.
By their numbers in this assay, from the lowest: compounds 2 and 3 (each within the scatter of the next); then compound 1.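

In this assay, putting 2,4-dimethoxyphenyl in place of 4-fluorophenyl on a double-bonded chain carbon bound to a double-bonded chain carbon gives a 1.2-fold higher number from compound 2 to compound 3 (0.07 log units; within the scatter). This is the first pair shown that differs in only one place, and it shows that this position can carry either group with no change beyond the scatter, although the entering group has more heavy atoms and carries hydrogen-bond acceptors, which the leaving group lacks. Nothing shown here bears on why the two numbers lie so close.

A single swap between two phenyl groups leaves open how much freedom this position really allows. Going by these compounds, it remains unknown how an amine, a carboxylic acid or a plain butyl chain at this position would affect growth inhibition.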